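Chalcone core: swapping a bromophenyl arm for thiophene

The compounds below may be only part of what the source reports. "The series", "measured", "known", "first", "only" and "open" are said of these compounds alone.

Compound 1 `COc1ccc(C(=O)/C=C/c2ccc(Br)cc2)c2c1C=CC(C)(C)O2`: > 10000 nM in a functional assay on HT-29 cells (Homo sapiens) for antiproliferative activity, read by MTT assay, with a stated time of 24 h; a higher number here means a weaker inhibitor, a lower number a stronger inhibitor
Compound 2 `COc1ccc(C(=O)/C=C/c2ccc(-c3ccccc3)cc2)c2c1C=CC(C)(C)O2`: > 10000 nM
Compound 3 `COc1ccc(C(=O)/C=C/c2ccc(C(F)(F)F)cc2)c2c1C=CC(C)(C)O2`: > 10000 nM

Compound 1 stands at a limit of this assay, not at a number. Compound 2 likewise stands at a limit in this assay. Compound 3 also stands at a limit in this assay. Each pairwise step among them is therefore unreadable: a step that the two limits leave unreadable from compound 1 to compound 2, a step that the two limits leave unreadable from compound 1 to compound 3 and a step that the two limits leave unreadable from compound 2 to compound 3 show no size, because of the limit of > 10000 nM in this assay, at which 3 of the 3 values shown sit.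

Compound 4 `COc1ccc(C(=O)/C=C/c2cccs2)c2c1C=CC(C)(C)O2` differs from compound 1 at the alkene end: thiophen-2-yl in place of 4-bromophenyl on a double-bonded chain carbon bound to a double-bonded chain carbon. Among the measured compounds shown here, no measured step bears on this change, since every recorded value is a limit. The account therefore expects compound 4 to behave like its three relatives, with a step that the limit leaves unreadable from compound 1 to compound 4 in this assay reflecting no readable shift. Compound 4 is estimated at 12000 nM in this assay, within 4000 nM to 40000 nM.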

Compound 4, half-maximal inhibitory concentration: > 10000 nM
Compound 4: no number, only a limit (the forecaster's own chance of this, stated with the estimate: 70%); the middle value is on the limit's open side.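

Compound 4 also stands at a limit in this assay, so no new step can be read, neither from compound 1 to compound 4 nor among the others, because: the limit of > 10000 nM in this assay, at which 4 of the 4 values shown sit.

The compounds shown leave open how thiophen-2-yl and 4-bromophenyl truly compare, and which change at this chain carbon, if any, would give a readable number in this assay.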